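Acyl chain trimming in a cytotoxicity series

A few compounds are considered here, and "the series" means these few. Any claim that something is new, unique, unknown or untested is made for them only; others in the source may bear on it.

Measured compounds:
compound 1 `CC(=O)c1ccc2c(c1O)[C@@H]1c3c(ccc4c(=O)c(C)c(C)oc34)OC[C@@H]1C(C)(C)O2`, > 100000 nM in a functional assay on HeLa cells (Homo sapiens) for cytotoxicity, read by MTT assay; a higher number here means a weaker inhibitor, a lower number a stronger inhibitor
compound 2 `CCC(=O)c1ccc2c(c1O)[C@H]1c3c(ccc4c(=O)c(C)coc34)OC[C@H]1C(C)(C)O2`, > 100000 nM in this assay

In this assay compound 2 gives > 100000 nM; this is a limit of the assay and not a number, so compound 2 stands only at the limit. Compound 1 also sits at a limit in this assay, and the two values together make (the limit of > 100000 nM in this assay, at which 2 of the 2 values shown sit).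

Compound 3 `CC(=O)c1ccc2c(c1O)[C@H]1c3c(ccc4c(=O)c(C)coc34)OC[C@H]1C(C)(C)O2` differs from compound 2 by hydrogen in place of methyl on a saturated chain carbon bound to a carbonyl carbon, or, cut one bond further out, propanoyl to acetyl. Within the data shown here, no step between measured compounds is at hand, so the size of this change has no direct precedent here. With both measured values at the limit, no step beyond the scatter is expected in this assay in either direction.

Compound 3 is therefore expected to give 100000 nM (range 40000 nM to 300000 nM), an estimated step of a number no higher from compound 2 to compound 3 (the limit leaves the size open).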

Compound 3, half-maximal inhibitory concentration: > 100000 nM
Compound 3: only a limit was reported; the forecaster's own chance of this, stated with the estimate: 80%; the middle value lies on the limit itself.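

No step can be read from compound 2 to compound 3 in this assay, because both values are limits and not numbers: the limit of > 100000 nM in this assay, at which 3 of the 3 values shown sit.

The compounds shown leave open whether propanoyl to acetyl changes the read-out in this assay at all, and what a value short of the limit would look like on the shared core.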